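The source may hold more compounds than are shown below. What is called first, only, known or untested is meant among the compounds shown, and "the series" means these compounds.

Compound 1, with the structure `O=C(/C=C\c1ccccc1[N+](=O)[O-])N1N=C(c2ccncc2)OC1c1c[nH]c2ccccc12`, is examined in an ADME assay on PANC-1 cells (Homo sapiens) for cytotoxicity, read by MTT assay, with a stated time of 48 h; a higher number here means a weaker inhibitor of growth, a lower number a stronger inhibitor of growth. In this assay compound 1 gives only a limit, > 30 ug/mL. Its two neighbours in the series carry the same core with a different aryl group on the double-bonded chain. Compound 2, `O=C(/C=C\c1ccc([N+](=O)[O-])cc1)N1N=C(c2ccncc2)OC1c1c[nH]c2ccccc12`, gives in this assay likewise only a limit, > 30 ug/mL. Compound 3, `COc1ccc(/C=C\C(=O)N2N=C(c3ccncc3)OC2c2c[nH]c3ccccc23)cc1`, gives in this assay again only a limit, > 30 ug/mL. The three measured steps are therefore all unreadable: from compound 1 to compound 2 the step is a step that the two limits leave unreadable from compound 1 to compound 2, from compound 1 to compound 3 it is a step that the two limits leave unreadable from compound 1 to compound 3, and from compound 2 to compound 3 it is a step that the two limits leave unreadable from compound 2 to compound 3. What unites the set is the limit of > 30 ug/mL in this assay, at which 3 of the 3 values shown sit.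

The unmeasured compound 4, `O=C(/C=C\c1cccc(F)c1)N1N=C(c2ccncc2)OC1c1c[nH]c2ccccc12`, differs from compound 1 in one place: 3-fluorophenyl in place of 2-nitrophenyl on a double-bonded chain carbon bound to a double-bonded chain carbon. Among the compounds with values here, none of the measured steps reads as a number, so no size can be carried over to this change; the only bearing the measured steps have is that every aryl variation so far has left compound 1, compound 2 and compound 3 at the same limit. Compound 4 is therefore expected to sit near or at that limit as well, with an estimated step from compound 1 of a step that the limit leaves unreadable from compound 1 to compound 4. Compound 4 is estimated at 40 ug/mL in this assay, within a range from 12 ug/mL to 120 ug/mL.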

Compound 4, concentration for 50% growth inhibition: > 30 ug/mL
Compound 4: no number, only a limit; the forecaster's own chance of this, stated with the estimate: 70%; the middle value is on the limit's open side.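

Compound 4 gives only a limit in this assay, as do compound 1, compound 2 and compound 3, so none of the steps from compound 4 to these compounds can be read: the limit of > 30 ug/mL in this assay, at which 4 of the 4 values shown sit. The compounds shown leave open how strongly any of the four inhibits growth, and whether any aryl group on the chain changes it.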